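Working notes on amine substitution around the shared core

The compounds below may be only part of what the source reports. "The series", "measured", "known", "first", "only" and "open" are said of these compounds alone.

Measured so far in a functional assay on HCT-116 cells (Homo sapiens) for cytotoxicity, read by MTT assay, with a stated time of 72 h; a lower number here means a stronger inhibitor, a higher number a weaker inhibitor:
compound 1 `O=C(NCc1ccc(F)cc1)c1nc(Br)c2cccnc2c1NCc1ccc(F)cc1` — > 20000 nM
compound 2 `N[C@H]1CC[C@H](NC(=O)c2nc(Br)c3cccnc3c2NCc2ccc(F)cc2)CC1` — 6400 nM
compound 3 `COC(=O)c1nc(Br)c2cccnc2c1N[C@H]1CC[C@H](N)CC1` — "not determined" (no result reported)

Compound 1 stands only at a limit in this assay, (the limit of > 20000 nM in this assay, at which 1 of the 3 values shown sits), so its own number is not known and it sits at the weak end of what has been seen. Compound 2, carrying 4-aminocyclohexyl in place of 4-fluorobenzyl on the amide-type nitrogen, gives an at least 3.1-fold lower number from compound 1 to compound 2 (0.49 log units; beyond the scatter), a step beyond the scatter. Compound 3 has no result in this assay, so it adds nothing to the comparison.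

Compound 4 `CNCCCNc1c(C(=O)NCc2ccc(F)cc2)nc(Br)c2cccnc12` is the next case. It differs from compound 1 by 2-(methylamino)ethyl in place of 4-fluorophenyl on a saturated chain carbon bound to a nitrogen on an aromatic ring. Among the measured compounds shown here, the change replaces a 4-fluorobenzyl with a chain bearing a nitrogen, as the change from compound 1 to compound 2 did, but at a different point of the molecule, and no measured pair covers that point. For the measured compounds named here, the only step that bears on it is the one from compound 1 to compound 2, which was at least modest and improving. A step of similar sense, but less certain, is expected from compound 1 to compound 4, an at least 2.2-fold lower number from compound 1 to compound 4 (0.34 log units; beyond the scatter). For compound 4 the estimate in this assay is 9000 nM, with a range from 2500 nM to 30000 nM.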

Compound 4, half-maximal inhibitory concentration: 9000 nM
Estimate against measurement, compound 4: no gap at the digits printed; the measured number falls inside the stated range.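

In this assay, the change from 4-fluorobenzyl to 3-(methylamino)propyl gives an at least 2.2-fold lower number from compound 1 to compound 4 (0.34 log units; beyond the scatter), a step beyond the scatter and the first to be read at this position on a saturated chain carbon bound to a nitrogen on an aromatic ring. The earlier step, an at least 3.1-fold lower number from compound 1 to compound 2 (0.49 log units; beyond the scatter), concerned only the amide-type nitrogen, so two different places on the shared core now each give a lower number when a 4-fluorobenzyl leaves, and the new step shows that a one-ring group can be exchanged here for a chain with no ring while a measurable number is kept. Compound 1 stands only at a limit of the assay, so the full size of the step stays unknown: the limit of > 20000 nM in this assay, at which 1 of the 4 values shown sits.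

From the compounds shown here alone, it remains open whether the nitrogen of the chain or the departure of the 4-fluorophenyl accounts for the step, which a plain butyl chain or a propyl chain ending in a hydroxyl would help to separate. Also open, going by these compounds, are the effect of chain length, with an ethyl or butyl linker, and of a primary or dimethylated amine in place of the methylamino end.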